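The compounds below may be only part of what the source reports. "The series", "measured", "known", "first", "only" and "open" are said of these compounds alone.

In an in vivo ADME assay on the whole organism for pharmacokinetics, with Rattus norvegicus as the target (on this read-out higher numbers stand for wider distribution into tissues and lower numbers for narrower distribution), compound 2 `Cc1cc(NC(=O)OC(C)(C)C)nn1Cc1cc(Cl)ccc1OCc1ccccc1` gives 8.6 L/kg, and compound 1 `Cc1cc(C(=O)NCc2ccccc2)nn1Cc1cc(Cl)ccc1OCc1ccccc1` gives 9.3 L/kg, the two standing together since the step of a 1.1-fold lower number from compound 1 to compound 2 (0.03 log units; within the scatter) falls within the scatter. Compound 3 `Cc1cc(NC(=O)OCc2ccccn2)nn1Cc1cc(Cl)ccc1OCc1ccccc1` differs from compound 2 by (pyridin-2-yl)methyl in place of tert-butyl on an oxygen next to a carbonyl group. Among the compounds with values here, the only measured step, from compound 1 to compound 2, alters a different place, so it gives no direct guide to this change; it shows merely that one exchange on the shared core left this assay almost unchanged. A step of a 1.2-fold lower number from compound 2 to compound 3 (0.09 log units; within the scatter) is therefore expected, most likely within the scatter. Compound 3 is estimated at 7 L/kg, ranging from 3 L/kg to 16 L/kg.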

Compound 3, volume of distribution at steady state: 3 L/kg
Estimate against measurement, compound 3: 2.3-fold (0.37 log units) above; the range from low to high includes it.
By their numbers in this assay, from the lowest: compound 3; then compounds 2 and 1 (each within the scatter of the next).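

In this assay, this oxygen next to a carbonyl group emerges as a place where the read-out can move: (pyridin-2-yl)methyl in place of tert-butyl gives a 2.9-fold lower number from compound 2 to compound 3 (0.46 log units; beyond the scatter), whereas the earlier exchange stayed within the scatter. Replacing benzylcarbamoyl on an aromatic carbon with (((pyridin-2-yl)methoxy)carbonyl)amino gives a similar result, a 3.1-fold lower number from compound 1 to compound 3 (0.49 log units; beyond the scatter). Nothing measured here explains this shift. Going by these compounds, whether the ring nitrogen of (pyridin-2-yl)methyl plays any part remains open, as does how a longer chain or an amine on this oxygen would read.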